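The source may hold more compounds than are shown below. What is called first, only, known or untested is meant among the compounds shown, and "the series" means these compounds.

Of the compounds shown here, three have been tested in a functional assay on BGC-823 cells (Homo sapiens) for cytotoxicity, read by MTT assay; on this read-out lower numbers stand for stronger inhibition and higher numbers for weaker inhibition: compound 1 `CC1=CCC23OC(C(C)(C)O)(CC12O)C(=O)C=C3C`, compound 2 `CC(C)[C@]1(O)C(=O)C[C@H](C)[C@@]12CC[C@](C)(O)C(=O)C2` and compound 3 `CC1=C[C@H](O)[C@]2(CC1=O)[C@H](C)CC(=O)[C@H]2C(C)C`. In this assay compound 1 gives > 10000 nM, which is a limit and not a number. Compound 2 gives > 10000 nM, which is also a limit. Compound 3 gives > 10000 nM, again a limit. The whole set therefore stands at the limit of > 10000 nM in this assay, at which 3 of the 3 values shown sit, and compound 3 has no exact potency to start from.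

Compound 4 `CC1=C[C@@H](O)[C@@]2(CC1=O)[C@@H](C(C)C)C(=O)C[C@@H]2C` is built from the same pieces as compound 3, and the comparison between them is purely one of spatial arrangement: the two compounds have the same atoms and bonds and differ only in configuration as drawn: 3 of 4 stereo elements differ; a stereocentre at a saturated ring carbon is drawn S in compound 3 and R in compound 4; a stereocentre at a saturated ring carbon is drawn S in compound 3 and R in compound 4; a stereocentre at a saturated ring carbon is drawn R in compound 3 and S in compound 4. Within the data shown here, no measured step shows what such a change does in this assay, so no shift beyond the usual scatter is expected, and compound 4 should probably remain at the limit too. The estimated change is a step that the limit leaves unreadable from compound 3 to compound 4. Compound 4 is expected to come in near 12000 nM, with an estimated range from 5000 nM to 30000 nM.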

Compound 4, half-maximal inhibitory concentration: > 10000 nM
Compound 4 ended at the assay's limit; the forecaster's own chance of this, stated with the estimate: 85%; the middle value is on the limit's open side.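

No step can be read from compound 3 to compound 4, since both values are limits and not numbers: the limit of > 10000 nM in this assay, at which 4 of the 4 values shown sit. The compounds shown leave open whether configuration has any effect in this assay, and what exact potency any of them has.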